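From 2-phenylethynyl to phenyl on the shared core

The compounds below may be only part of what the source reports. "The series", "measured", "known", "first", "only" and "open" are said of these compounds alone.

Measured in a functional assay on Z-138 cells (Homo sapiens) for antiproliferative activity, with a stated time of 72 h; a higher number here means a weaker inhibitor, a lower number a stronger inhibitor:
- compound 1 `Nc1ncnn2c([C@@H]3O[C@H](CO)[C@@H](O)[C@H]3O)cc(C#CC3CC3)c12`: 20 nM
- compound 2 `Nc1ncnn2c([C@@H]3O[C@H](CO)[C@@H](O)[C@H]3O)cc(C#Cc3cccs3)c12`: 50100 nM
- compound 3 `Nc1ncnn2c([C@@H]3O[C@H](CO)[C@@H](O)[C@H]3O)cc(C#Cc3ccccc3)c12`: 41400 nM

Compound 3 sits at the weak end of this small set, level with its thiophene counterpart: a 1.2-fold lower number from compound 2 to compound 3 (0.08 log units; within the scatter). Compound 4 `Nc1ncnn2c([C@@H]3O[C@H](CO)[C@@H](O)[C@H]3O)cc(-c3ccccc3)c12` carries phenyl in place of 2-phenylethynyl on an aromatic carbon. Among the measured compounds shown here, no measured step removes the triple bond, so the evidence is indirect. Swapping the group on the triple-bonded carbon gave large steps from the cyclopropyl compound, a 2500-fold higher number from compound 1 to compound 2 (3.40 log units; beyond the scatter) and a 2100-fold higher number from compound 1 to compound 3 (3.32 log units; beyond the scatter), but compound 4 keeps the phenyl ring of compound 3. No step beyond the scatter is therefore expected in this assay, though with wide uncertainty. The expected step is a 1.7-fold lower number from compound 3 to compound 4 (0.22 log units; within the scatter). For compound 4 the estimated value is 25000 nM, within an expected range of 3000 nM to 80000 nM.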

Compound 4, half-maximal inhibitory concentration: > 100000 nM
Compound 4: no number, only a limit; the forecaster's own chance of this, stated with the estimate: 35%; middle value at least 4.0-fold (0.60 log units) from the limit.
By their numbers in this assay, from the lowest: compound 1; then compounds 3 and 2 (each within the scatter of the next). At a limit, above all of these: compound 4.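

In this assay compound 4 gives only a limit, not a number: the limit of > 100000 nM in this assay, at which 1 of the 4 values shown sits. Setting phenyl directly on the aromatic carbon, with no triple bond, therefore brings no gain at this position, and the step is an at least 2.4-fold higher number from compound 3 to compound 4 (0.38 log units; beyond the scatter). The two further steps are an at least 1.9-fold higher number from compound 2 to compound 4 (0.30 log units; that floor lies within the scatter) and an at least 5000-fold higher number from compound 1 to compound 4 (3.69 log units; beyond the scatter).

On these data alone, what a cyclopropyl group or an amine set directly on that aromatic carbon would give stays open. So does whether the triple bond or the cyclopropyl group on it matters more for compound 1.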